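Removing the Nitro Group from Compound 1

This account rests on a few compounds, and the source may have more. Where it says the series, first, only, none or still open, it means among the compounds named here.

Measured in an ADME assay on MDBK cells (Bos taurus) for cytotoxicity, read by MTT assay, with a stated time of 96 h; on this read-out higher numbers stand for lower toxicity in this test and lower numbers for higher toxicity in this test:
- Compound 1 `CN(C)CCCN(/N=N/c1ccc([N+](=O)[O-])cc1)c1ccccc1`: 39000 nM
- Compound 2 `CN(C)CCCNc1ccc(/N=N/c2ccccc2)cc1`: 58000 nM
- Compound 3 `Clc1ccc(/N=N/N2CCCC2)cc1`: > 100000 nM, a limit of the assay and not a number

Within the data shown here, compound 1 and compound 2 are the only two with actual numbers, and those numbers lie within the usual scatter of each other. Compound 4 `CN(C)CCCN(/N=N/c1ccccc1)c1ccccc1` has hydrogen in place of nitro on an aromatic carbon of the core of compound 1, para to a large group (hydrogen in place of nitro on an aromatic carbon). Among the measured compounds shown here, no measured pair isolates this change, so no shift beyond the scatter is expected in this assay. The expected 1.3-fold higher number from compound 1 to compound 4 (0.11 log units; within the scatter) is therefore small. Compound 4 is estimated at 50000 nM, with an expected range from 20000 nM to 100000 nM.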

Compound 4, half-maximal cytotoxic concentration: 95000 nM
Compound 4: the middle estimate sits 1.9-fold (0.28 log units) below what was measured, and the stated range covers the measured number.
By their numbers in this assay, from the lowest: compounds 1, 2 and 4 (each within the scatter of the next, the first and the last beyond it). At a limit, above all of these: compound 3.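

In this assay, hydrogen in place of nitro on an aromatic carbon, para to a large group, gives a 2.4-fold higher number from compound 1 to compound 4 (0.39 log units; beyond the scatter). The earlier compounds shown here differ in more than one place, so they could not show that this single change moves the read-out at all. Here it moves modestly towards lower toxicity in this test.

From the compounds shown here alone, whether an amine or a methoxy group at this position would fall nearer compound 1 or compound 4 stays open. Compound 4 also stands close to the top of what this assay can read, leaving little room for any further rise to show: the limit of > 100000 nM in this assay, at which 1 of the 4 values shown sits.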